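The source may report more compounds than this note shows. Statements on the series, on what has been measured and on what is new or still open speak of the compounds shown alone.

Values so far in a functional assay on MCF7 cells (Homo sapiens) for antiproliferative activity, read by MTT assay, with a stated time of 48 h; a lower number here means a stronger inhibitor, a higher number a weaker inhibitor:
compound 1 `COc1ccc(C2=N/C(=C\c3cc(Br)cc(Br)c3OC(C)=O)C(=O)NN2C(N)=S)cc1OC`: 13400 nM
compound 2 `COc1cc(C2=N/C(=C\c3cc(Br)cc(Br)c3OC(C)=O)C(=O)NN2C(N)=S)cc(OC)c1OC`: 360 nM

In this assay, compound 2 has the lower of the two numbers, at 360 nM. For the measured compounds named here, the only measured step is a 37-fold lower number from compound 1 to compound 2 (1.57 log units; beyond the scatter), for methoxy in place of hydrogen on an aromatic carbon. It is large and beyond the scatter.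

Compound 3 `COc1cc(C2=N/C(=C\c3cc(Br)cc(Br)c3OC(C)=O)C(=O)NN2c2ncc(-c3ccccc3)s2)cc(OC)c1OC` differs from compound 2 elsewhere: a group of 11 heavy atoms (9 carbon, 1 nitrogen, 1 sulfur; one five-membered aromatic ring with 2 hetero atoms, one six-membered aromatic ring of carbon only) in place of a group of 3 heavy atoms (1 carbon, 1 nitrogen, 1 sulfur; no ring), on an amine nitrogen in a ring. The entering group is 5-phenyl-1,3-thiazol-2-yl, on an amine nitrogen in a ring. Going by the values given here, no measured step covers this place, so a 37-fold lower number from compound 1 to compound 2 (1.57 log units; beyond the scatter) bears on it only indirectly, as a sign that a single change can move the number a long way. A moderate rise is expected, with wide uncertainty in either direction. The expected change is a 2.5-fold higher number from compound 2 to compound 3 (0.40 log units; beyond the scatter). Compound 3 is estimated at 900 nM, with an expected range of 120 nM to 6300 nM.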

Compound 3, half-maximal inhibitory concentration: 410 nM
Compound 3: middle estimate off by 2.2-fold (0.34 log units), on the high side; low and high end bracket the measured number.
By their numbers in this assay, from the lowest: compounds 2 and 3 (each within the scatter of the next); then compound 1.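

At the amine nitrogen in a ring, 5-phenyl-1,3-thiazol-2-yl in place of the group of 3 heavy atoms gives a 1.1-fold higher number from compound 2 to compound 3 (0.06 log units; within the scatter) in this assay, so this position takes a far larger group with two aromatic rings and the number stays within the scatter. The entering group has 0 hydrogen-bond donors against 1 in the leaving group, so in this pair that donor and the double bond outside aromatic rings are not required for a number at this level. No measurement at hand explains why two such different groups give matching numbers.

Whether the phenyl on the thiazole matters stays open, as the compounds shown include neither a thiazol-2-yl without phenyl nor a phenyl carrying an amine or a carboxylic acid. Also open, as far as these compounds go, is whether the same exchange gives a matching result on the core of compound 1, which has one methoxy fewer.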